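The source may hold more compounds than are shown below. What is called first, only, known or untested is meant among the compounds shown, and "the series" means these compounds.

Compounds measured in an assay for inhibition of acid-sensing ion channel 3 (Homo sapiens), read by patch clamp, tested at 1 uM; a lower number here means less inhibition, a higher number more inhibition at the concentration tested (going by the name of the read-out):
compound 1 `CCCNc1nc(N)c(C(=O)N=C(N)N)nc1Cl`: 24%
compound 2 `NC(N)=NC(=O)c1nc(Cl)c(NC2CC2)nc1N`: "not determined" (no result reported)
compound 3 `CCCN(C)c1nc(N)c(C(=O)N=C(N)N)nc1Cl`: 32%

For the measured compounds named here, compound 3 gives one of only two numbers in this assay, and it cannot be told apart from compound 1, since the step of a number 8 percentage points higher from compound 1 to compound 3 (within the scatter) lies within the usual scatter. Compound 4 `NC(N)=NC(=O)c1nc(Cl)c(N2CCCC2)nc1N` differs from compound 3 by pyrrolidin-1-yl in place of methyl(propyl)amino on an aromatic carbon. Going by the values given here, the only measured step, from compound 1 to compound 3, also changed the group on this same aromatic carbon and produced no change beyond the scatter; nothing else bears on the question. On that basis the step of a number 2 percentage points lower from compound 3 to compound 4 (within the scatter) is expected to stay within the scatter. Compound 4 is therefore estimated at 30%, with a range from 10% to 55%.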

Compound 4, a percentage reported as inhibition, at one concentration (the size of the read-out at that concentration, not a potency): 12%
Beside the measured number, compound 4's estimate is 18 percentage points above it, and the stated range covers the measured number.
By their numbers in this assay, from the lowest: compound 4; then compounds 1 and 3 (each within the scatter of the next).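

In this assay this aromatic carbon proves sensitive to its group, with a number 20 percentage points lower from compound 3 to compound 4 (beyond the scatter) even though pyrrolidin-1-yl and methyl(propyl)amino carry the same heavy atoms. Pyrrolidin-1-yl also stands apart from propylamino, with a number 12 percentage points lower from compound 1 to compound 4 (beyond the scatter) and so, among these three compounds, the ring goes with the lowest number. Nothing measured here gives a reason for this difference.

Going by these compounds, whether a larger ring such as piperidin-1-yl, or a longer chain on the nitrogen, would read lower or higher stays open. Compound 2, with its cyclopropylamino group, offers no number for comparison.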